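A few compounds are considered here, and "the series" means these few. Any claim that something is new, unique, unknown or untested is made for them only; others in the source may bear on it.

Working notes on the aminothiophene series.

Compound 1 `Nc1sc2c(c1C(=O)NCc1cccc(Cl)c1)CCN(Cc1ccccc1)C2` carries a benzyl group on the ring nitrogen and a chlorobenzyl amide. In an in vitro assay on CHOk1 cells with adenosine receptor A1 (Homo sapiens) as the target (on this read-out lower numbers stand for an effect already at smaller amounts and higher numbers for an effect only at larger amounts of compound), compound 1 reaches only a limit of the assay, > 20000 nM, and no number. Compound 2 `CN1CCc2c(sc(N)c2C(=O)NCc2cccc(Cl)c2)C1` keeps the amide and differs at the ring nitrogen; the change is hydrogen in place of phenyl on a saturated chain carbon bound to an amine nitrogen in a ring. In this assay compound 2 gives 13200 nM. The step of an at least 1.5-fold lower number from compound 1 to compound 2 (0.18 log units; that floor lies within the scatter) is known only as a floor, since one of the three values sits at the limit of > 20000 nM in this assay, at which 1 of the 3 values shown sits.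

Compound 3 `N#Cc1c(N)sc2c1CCN(Cc1ccccc1)C2` replaces the amide with a nitrile while retaining the benzyl group; the difference between the core of compound 3 and that of compound 1 is not broken down here. In this assay compound 3 gives 15200 nM, which lies within the scatter of the value of compound 2.

Compound 4 `CN1CCc2c(sc(N)c2C#N)C1` stands to compound 3 as compound 2 stands to compound 1: the change is hydrogen in place of phenyl on a saturated chain carbon bound to an amine nitrogen in a ring, and both changes sit at the same place, so it is the same change. For the measured compounds named here, the one earlier step of this kind is itself only a floor, and the expectation rests on it alone. The step expected for compound 4 is a 1.5-fold lower number from compound 3 to compound 4 (0.18 log units; within the scatter), that is a somewhat lower number. Compound 4 is therefore estimated at 10000 nM in this assay, with a range of 4000 nM to 25000 nM, and a real chance that only a limit is returned.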

Compound 4, half-maximal effective concentration: > 20000 nM
Compound 4 ended at the assay's limit; the forecaster's own chance of this, stated with the estimate: 25%; middle value at least 2.0-fold (0.30 log units) from the limit.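

In this assay compound 4 returns only a limit of the assay, > 20000 nM, and no number. The change of phenyl to hydrogen on a saturated chain carbon bound to an amine nitrogen in a ring can therefore be read on this core only as a floor, an at least 1.3-fold higher number from compound 3 to compound 4 (0.11 log units; that floor lies within the scatter), and it says nothing about how large the true step is. Set beside the earlier step on the core of compound 1, this result shows neither that the change carries from one core to the other nor that it behaves differently on the two, so no step for this change can yet be transferred between cores in this series: the same change on two cores in this assay, an at least 1.5-fold lower number (0.18 log units; that floor lies within the scatter) from compound 1 to compound 2 and an at least 1.3-fold higher number (0.11 log units; that floor lies within the scatter) from compound 3 to compound 4; the limit leaves it open whether they differ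

Open, going by these compounds, is whether a longer chain, an amine or a carboxylic acid in place of the phenyl, on the same saturated chain carbon bound to an amine nitrogen in a ring, would give numbers on both cores that could be compared directly. Also open is where compound 1 and compound 4 really stand, and any comparison that includes them stays incomplete for as long as this holds: the limit of > 20000 nM in this assay, at which 2 of the 4 values shown sit.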